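This account rests on a few compounds, and the source may have more. Where it says the series, first, only, none or still open, it means among the compounds named here.

The measured compounds are compound 1 `Nc1ccccc1NC(=O)c1ccc(CSC(=S)N2CCc3ccc([N+](=O)[O-])cc32)cc1` with 39.6%, compound 2 `Nc1ccccc1NC(=O)c1ccc(CSC(=S)N2CCCc3ccccc32)cc1` with 87.5%, and compound 3 `Nc1ccccc1NC(=O)c1ccc(CSC(=S)N(Cc2ccccc2)Cc2ccccc2)cc1` with 30.7%.

In a functional assay on MGC-803 cells (Homo sapiens) for antiproliferative activity, read by CCK-8 assay, with a stated time of 72 h, tested at 8 uM (a lower number here means a weaker effect, a higher number a stronger effect of the compound at the concentration tested), compound 2 stands highest of the three numbers. Compound 1 sits a long way below it, beyond the scatter, and compound 3 sits lower still, also beyond the scatter. Within the data shown here, the three compounds share a common core and differ only in the group on the thiocarbonyl carbon, so the numbers show that this group matters, though no pair of measured compounds isolates a single small change there.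

Compound 4 `Nc1ccccc1NC(=O)c1ccc(CSC(=S)N2CCCC2)cc1` differs from compound 2 in one place: pyrrolidin-1-yl in place of 1,2,3,4-tetrahydroquinolin-1-yl on a thiocarbonyl carbon. Nothing measured tells how this particular change behaves, but both other groups tried at that position, in compound 1 with 39.6% and in compound 3 with 30.7%, fall well short of compound 2, so a drop beyond the scatter in this assay seems the more likely outcome, with wide uncertainty.

Compound 4 is expected to give 45%, plausibly between 15% and 80%. The expected step of a number 42.5 percentage points lower from compound 2 to compound 4 (beyond the scatter) is a decrease beyond the scatter.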

Compound 4, a percentage reported as inhibition, at one concentration (the size of the read-out at that concentration, not a potency): 83.4%
Compound 4: middle estimate off by 38.4 percentage points, on the low side; the measured number lies above the stated range.
By their numbers in this assay, from the lowest: compounds 3 and 1 (each within the scatter of the next); then compounds 4 and 2 (each within the scatter of the next).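

Replacing 1,2,3,4-tetrahydroquinolin-1-yl with pyrrolidin-1-yl on a thiocarbonyl carbon leaves the read-out in this assay essentially unchanged (a number 4.1 percentage points lower from compound 2 to compound 4 (within the scatter)). The six-membered aromatic ring that leaves with the 1,2,3,4-tetrahydroquinolin-1-yl group is therefore not needed for a high read-out at this concentration, and this position accepts at least two different ring-bearing groups, one of them with no aromatic ring. Nothing available here explains why these two groups read alike.

On these data alone, it remains open whether a piperidin-1-yl group, a morpholin-4-yl group or an open-chain diethylamino group on the same thiocarbonyl carbon would hold this level. As far as these compounds go, since a read-out at one concentration is not a potency, it also remains open whether compound 2 and compound 4 would separate across a range of concentrations.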